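The source may hold more compounds than are shown below. What is called first, only, known or untested is meant among the compounds shown, and "the series" means these compounds.

In a functional assay on MDA-MB-435 cells (Homo sapiens) for antiproliferative activity, read by sulforhodamine B assay, with a stated time of 72 h (on this read-out higher numbers stand for weaker inhibition and lower numbers for stronger inhibition), compound 1 `NC(=S)NNc1nncc2ccccc12` gives 52 nM, compound 2 `Cc1cc(NS(=O)(=O)c2ccc(Nc3nncc4ccccc34)cc2)no1` gives 27 nM and compound 3 `Cc1cc(C)nc(NS(=O)(=O)c2ccc(Nc3nncc4ccccc34)cc2)n1` gives 3.4 nM. Compound 3 stands lowest of the three numbers, with compound 2 nearest and compound 1 furthest. Compound 4 `O=S(=O)(Nc1nccs1)c1ccc(Nc2nncc3ccccc23)cc1` carries the change (1,3-thiazol-2-yl in place of 4,6-dimethylpyrimidin-2-yl on a sulfonamide nitrogen). Within the data shown here, the single measured step at the same sulfonamide nitrogen is a 7.9-fold lower number from compound 2 to compound 3 (0.90 log units; beyond the scatter), in which a six-membered aromatic ring with 2 hetero atoms replaced a five-membered aromatic ring with 2 hetero atoms; compound 4 returns to a five-membered aromatic ring with 2 hetero atoms, so part of that gain is expected to be given back and a higher number is expected in this assay. The expected step is a 3.5-fold higher number from compound 3 to compound 4 (0.55 log units; beyond the scatter). Compound 4 is estimated at 12 nM, with a range from 4 nM to 40 nM.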

Compound 4, half-maximal inhibitory concentration: 36 nM
Estimate against measurement, compound 4: 3.0-fold (0.48 log units) below, and the stated range covers the measured number.
By their numbers in this assay, from the lowest: compound 3; then compounds 2, 4 and 1 (each within the scatter of the next).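

In this assay the step back to a five-membered aromatic ring is an 11-fold higher number from compound 3 to compound 4 (1.02 log units; beyond the scatter) and so gives back the whole gain seen at this sulfonamide nitrogen, not part of it. The two five-membered rings cannot be told apart, with a 1.3-fold higher number from compound 2 to compound 4 (0.12 log units; within the scatter), so 4,6-dimethylpyrimidin-2-yl alone stands apart among these three groups. No evidence on the cause of this step is available.

Still open, as far as these compounds go, is whether the lower number of compound 3 goes with the six-membered ring or with its methyl groups. An unsubstituted pyrimidin-2-yl on the same nitrogen would separate the two.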